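Stretching the para alkyl chain on a urea

This account rests on a few compounds, and the source may have more. Where it says the series, first, only, none or still open, it means among the compounds named here.

Compound 1 `Cc1ccc(NC(=O)N[C@H](C)c2ccccc2)cc1` gives 98% in an ADME assay on the whole organism with Oryza sativa as the target, tested at 1 uM; a higher number here means a weaker effect of the compound at the concentration tested, a lower number a stronger effect. Compound 2 `CC(C)c1ccc(NC(=O)N[C@H](C)c2ccccc2)cc1` gives 79%, the lowest of the three numbers measured, and compound 3 `CC(C)c1ccc(NC(=O)N[C@@H](C)c2ccccc2)cc1` gives 96%. The step from compound 1 to compound 2 was a number 19 percentage points lower from compound 1 to compound 2 (beyond the scatter); the step from compound 2 to compound 3 was a number 17 percentage points higher from compound 2 to compound 3 (beyond the scatter), and these two compounds differ only in configuration as drawn (the fact that compounds 2 and 3 differ only in the configuration as drawn). Compound 4 `CCCCCc1ccc(NC(=O)N[C@H](C)c2ccccc2)cc1` keeps the configuration of compound 2 and changes only the group on the ring (pentyl in place of isopropyl on an aromatic carbon). Among the measured compounds shown here, of the measured steps only the one from compound 1 to compound 2 concerns a change of the alkyl group, and it points downward. Going from compound 2 to compound 4 the expected step is therefore a number 14 percentage points lower from compound 2 to compound 4 (beyond the scatter). For compound 4 the estimate is 65%, with a range from 40% to 90%.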

Compound 4, a percentage reported as activity, at one concentration (the size of the read-out at that concentration, not a potency): 101%
Estimate against measurement, compound 4: 36 percentage points below; measured number outside the range, above it.
By their numbers in this assay, from the lowest: compound 2; then compounds 3, 1 and 4 (each within the scatter of the next).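

Lengthening the group at this position does not keep strengthening the effect in this assay: pentyl in place of isopropyl gives a number 22 percentage points higher from compound 2 to compound 4 (beyond the scatter). Compared with the methyl group, pentyl gives a number 3 percentage points higher from compound 1 to compound 4 (within the scatter), so the two chain ends of this short series do not separate. Among compounds 1, 2 and 4, the stronger effect belongs to isopropyl alone, so the link between group size and effect is not a steady one.

Nothing available explains why isopropyl stands apart. On these data alone, whether a propyl or tert-butyl group in this place would behave like isopropyl remains open.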